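The source may report more compounds than this note shows. Statements on the series, on what has been measured and on what is new or still open speak of the compounds shown alone.

Measured so far:
Compound 1, `CCN(CC)CCCOc1ccc2cc(NC(=O)c3ccc(O)c(CC=C(C)C)c3)c(=O)oc2c1C`: 6390 nM
Compound 2, `CC(C)=CCc1cc(C(=O)Nc2cc3ccc(OCCCNC(C)C)c(C)c3oc2=O)ccc1O`: 740 nM

Both compounds were tested in a functional assay on MCF7 cells (Homo sapiens) for antiproliferative activity; on this read-out lower numbers stand for stronger inhibition and higher numbers for weaker inhibition. Compound 2 stands at the lowest of the two numbers, with compound 1 the nearest and the only other, the step being an 8.6-fold lower number from compound 1 to compound 2 (0.94 log units; beyond the scatter). The structural change between them is isopropylamino in place of diethylamino on a saturated chain carbon, three bonds along the chain from an oxygen on an aromatic ring.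

Compound 3, `CC(C)=CCc1cc(C(=O)Nc2cc3ccc(OCCCNCC(N)=O)c(C)c3oc2=O)ccc1O`, has not yet been measured. It differs from compound 2 in one place: carbamoylmethyl in place of isopropyl on an amine nitrogen. For the measured compounds named here, the only measured step, an 8.6-fold lower number from compound 1 to compound 2 (0.94 log units; beyond the scatter), concerns the group on this same amine nitrogen, so it bears on the new step, but it swapped one alkyl group for another, whereas here an alkyl group gives way to one carrying a donor and an acceptor. Going by the values given here, no measured pair shows that kind of change, so the direction is uncertain; the expectation is a modest rise in the number, near the edge of the scatter, a 2.0-fold higher number from compound 2 to compound 3 (0.31 log units; beyond the scatter). Compound 3 is therefore estimated at 1500 nM, within a range from 400 nM to 6000 nM.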

Compound 3, half-maximal inhibitory concentration: 1460 nM
Compound 3: middle estimate off by 1.0-fold (0.01 log units), on the high side, within the range that was stated.
By their numbers in this assay, from the lowest: compounds 2 and 3 (each within the scatter of the next); then compound 1.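

In this assay, the step of a 2.0-fold higher number from compound 2 to compound 3 (0.30 log units; within the scatter) shows that carbamoylmethyl, which brings a hydrogen-bond donor and acceptor absent from isopropyl, can stand on this amine nitrogen without a change that rises above the scatter. The step of a 4.4-fold lower number from compound 1 to compound 3 (0.64 log units; beyond the scatter) shows that the earlier gain over diethylamino is not unique to isopropylamino, since (carbamoylmethyl)amino also gives a lower number than diethylamino. No supporting measurement is available to explain either result.

Open, from the compounds shown here alone, is whether the gain depends on the group that remains on the nitrogen or simply on replacing diethylamino, which ethylamino or an unsubstituted amine could help to separate. Also open, going by these compounds, is how a carboxylic acid in place of the terminal amide of carbamoylmethyl would read in this assay.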